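This account rests on a few compounds, and the source may have more. Where it says the series, first, only, none or still open, it means among the compounds named here.

Compound 1 `CCCCC#Cc1cc2cn([C@H]3C[C@H](O)[C@@H](CO)O3)c(=O)nc2o1` gives > 150000 nM in a functional assay on HEL cells (Homo sapiens) for cytotoxicity (a higher number here means that more compound is tolerated, a lower number that less compound is tolerated), which is a limit of the assay.
Compound 2 `CCCCCCC#Cc1cc2cn([C@H]3C[C@H](O)[C@@H](CO)O3)c(=O)nc2o1` gives >= 97000 nM in this assay, also a limit of the assay.

Compound 2 therefore stands only at a limit, as the limit of >= 97000 nM in this assay, at which 1 of the 2 values shown sits, shows, and compound 1 at another, (the limit of > 150000 nM in this assay, at which 1 of the 2 values shown sits). For the measured compounds named here, the one measured step, a step that the two limits leave unreadable from compound 1 to compound 2, is the same kind of change as the one ahead, yet its size cannot be read. Compound 3 `CCCCCCCCC#Cc1cc2cn([C@H]3C[C@H](O)[C@@H](CO)O3)c(=O)nc2o1` differs from compound 2 by ethyl in place of hydrogen on a saturated chain carbon, six bonds along the chain from a triple-bonded carbon. No step beyond the scatter is expected from that, and compound 3 is expected again to reach a limit. Compound 3 is estimated at 100000 nM, between 40000 nM and 300000 nM, an expected step that the limit leaves unreadable from compound 2 to compound 3.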

Compound 3, minimum cytotoxic concentration: 52000 nM
For compound 3 the middle estimate is 1.9-fold (0.28 log units) above the measured one; the range from low to high includes it.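

Compound 3 gives a measured number in this assay, not a limit, so ethyl at this place, six bonds along the chain from a triple-bonded carbon, gives the first readable result in the series. The step is an at least 1.8-fold lower number from compound 2 to compound 3 (0.27 log units; that floor lies within the scatter), and because that floor lies within the scatter, it does not establish a change on its own. Over the whole chain extension, the step is an at least 2.8-fold lower number from compound 1 to compound 3 (0.46 log units; beyond the scatter), which is beyond the scatter, while the earlier step cannot be read. The compounds shown leave open where along the chain the tolerated concentration begins to fall, and whether a longer chain or an amine would lower it further.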